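The compounds below may be only part of what the source reports. "The series", "measured", "known", "first", "only" and "open" are said of these compounds alone.

Measured compounds:
compound 1 `CCc1cc2c(C(=O)c3ccc(OC)cc3)c(OC)ccc2o1`, 6.1%
compound 2 `CCc1oc2ccc(OC)cc2c1C(=O)c1ccc(O)cc1`, 92.7%
compound 3 `CCc1oc2ccc(O)cc2c1C(=O)c1ccc(O)cc1`, 96.5%

All three were tested in an assay for inhibition of solute carrier family 22 member 12 (Homo sapiens), read by scintillation counting, with a stated time of 60 min, tested at 50 uM; a higher number here means more inhibition at the concentration tested (going by the name of the read-out), a lower number less inhibition. Compound 1 stands lowest of the three; compound 2 sits well above it, and compound 3 above that. How the core of compound 1 differs from that of compound 2 is not broken down here.

From compound 2 to compound 3 the change is hydrogen in place of methyl on an oxygen on an aromatic ring, and the step is a number 3.8 percentage points higher from compound 2 to compound 3 (within the scatter). The same change is now applied to compound 1, giving compound 4 `CCc1cc2c(C(=O)c3ccc(O)cc3)c(OC)ccc2o1`: hydrogen in place of methyl on an oxygen on an aromatic ring.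

From the compounds shown here alone, because compound 1 starts from 6.1% while compound 2 already reaches 92.7%, the earlier step gives little room to show an effect; on compound 1 the same change is expected to yield a larger step, a number 33.9 percentage points higher from compound 1 to compound 4 (beyond the scatter), though the contribution of the different core is unknown. Compound 4 is therefore estimated at 40%, in the range 8% to 80%.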

Compound 4, a percentage reported as inhibition, at one concentration (the size of the read-out at that concentration, not a potency): 88.2%
For compound 4 the middle estimate is 48.2 percentage points below the measured one; the whole stated range lies below it.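

In this assay the change from methoxy to hydroxy on the core of compound 1 gives a number 82.1 percentage points higher from compound 1 to compound 4 (beyond the scatter) and restores a high reading. The size of this step does not carry over from one core to the other: the same change on two cores in this assay, a number 3.8 percentage points higher (within the scatter) from compound 2 to compound 3 and a number 82.1 percentage points higher (beyond the scatter) from compound 1 to compound 4, 78.3 percentage points apart, beyond the scatter of two such steps.

Among these compounds, these are readings at a single concentration on only two cores, so they give no potency and do not show which feature of the cores sets the gap; compound 2 already reads 92.7% before the change.

The compounds shown leave open whether an amine or a carboxylic acid could stand in place of that hydroxy on either core. Also open, from the compounds shown here alone, is how a longer chain in place of the ethyl would read.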